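Working notes: chloro in place of nitro

The source may hold more compounds than are shown below. What is called first, only, known or untested is meant among the compounds shown, and "the series" means these compounds.

Measured in a functional assay on the whole organism with Mus musculus as the target (a lower number here means that less compound is needed, a higher number that more compound is needed for the effect), so far:
- compound 1 `COc1cc2c(cc1OC)C(c1cccc(N)c1)=NN=C(S)C2` gives 18.8 umol/kg
- compound 2 `COc1cc2c(cc1OC)C(c1ccc([N+](=O)[O-])cc1)=NN=C(S)C2` gives 93.4 umol/kg
- compound 3 `COc1cc2c(cc1OC)C(c1cccc([N+](=O)[O-])c1)=NNC(=O)C2` gives > 120 umol/kg as a limit of the assay

Compound 2 (93.4 umol/kg) holds the higher of the two actual numbers, and compound 1 (18.8 umol/kg) lies lower by a gap beyond the usual scatter. The entry for compound 3 (> 120 umol/kg) is a limit and not a number.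

Compound 4 `COc1cc2c(cc1OC)C(c1ccc(Cl)cc1)=NN=C(S)C2` keeps the core of compound 2 and carries chloro in place of nitro on an aromatic carbon, para to a large group (chloro in place of nitro on an aromatic carbon). Going by the values given here, no two measured compounds differ in one place only, so the series offers no direct precedent for the size of this step. Compound 1 (18.8 umol/kg) shows that the shared core can reach a lower number than compound 2 (93.4 umol/kg), but that gap does not come from a single change. The expected step (a 1.6-fold lower number from compound 2 to compound 4 (0.19 log units; within the scatter)) is therefore small, towards a lower number and within the usual scatter. In this assay compound 4 is estimated at 60 umol/kg, with an expected range from 22 umol/kg to 130 umol/kg as the outer ends.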

Compound 4, dose for half-maximal effect: 82.4 umol/kg
Beside the measured number, compound 4's estimate is 1.4-fold (0.14 log units) below it; measured number inside the range.
By their numbers in this assay, from the lowest: compound 1; then compounds 4 and 2 (each within the scatter of the next). At a limit, above all of these: compound 3.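

Going by these compounds alone, the first single-place comparison shows that, in this assay, nitro and chloro on this aromatic carbon, para to a large group, cannot be told apart, with a 1.1-fold lower number from compound 2 to compound 4 (0.05 log units; within the scatter). The gap to the amine-bearing compound 1 remains, with a 4.4-fold higher number from compound 1 to compound 4 (0.64 log units; beyond the scatter), but this step exchanges 3-aminophenyl for 4-chlorophenyl, so it ties the gap to the whole aryl group and cannot separate the amine from its place on the ring. Steps to compound 3 cannot be read, since compound 3 carries a limit of the assay and not a number: the limit of > 120 umol/kg in this assay, at which 1 of the 4 values shown sits.

The compounds shown leave open whether the amino group itself or its place on the ring accounts for the lower number of compound 1, a question that 4-aminophenyl and 3-chlorophenyl on the shared core would address. They also leave open whether the match between nitro and chloro extends to other groups at this place, such as a carboxylic acid, a hydroxyl or a longer alkyl chain.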